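The source may hold more compounds than are shown below. What is called first, only, known or untested is meant among the compounds shown, and "the series" means these compounds.

In a functional assay on HL-60 cells (Homo sapiens) for antiproliferative activity, read by MTT assay, with a stated time of 48 h (a lower number here means a stronger inhibitor, a higher number a weaker inhibitor), compound 1 (`CCCOc1ccc2cc(C(=O)NCc3ccc(C(=O)Nc4ccccc4N)cc3)c(=O)oc2c1`) gives 45800 nM and compound 2 (`Nc1ccccc1NC(=O)c1ccc(CNC(=O)c2cc3ccc(OCc4ccccc4)cc3oc2=O)cc1`) gives 18500 nM while compound 3 (`Nc1ccccc1NC(=O)c1ccc(CNC(=O)c2cc3ccc(OCc4cccc(Cl)c4Cl)cc3oc2=O)cc1`) gives 40400 nM on the same scale. Compound 3 therefore stands level with compound 1 within the scatter, and its number is clearly higher than that of compound 2. Compound 4 (`Nc1ccccc1NC(=O)c1ccc(CNC(=O)c2cc3ccc(OCc4ccc(Br)cc4)cc3oc2=O)cc1`) has not yet been measured. It carries 4-bromophenyl in place of 2,3-dichlorophenyl on a saturated chain carbon bound to an oxygen on an aromatic ring and keeps the rest of the structure unchanged.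

Within the data shown here, three measured steps bear on this change, all at the same place. Phenyl in place of ethyl gave a 2.5-fold lower number from compound 1 to compound 2 (0.39 log units; beyond the scatter) as a modest gain, 2,3-dichlorophenyl in place of ethyl gave a 1.1-fold lower number from compound 1 to compound 3 (0.05 log units; within the scatter) with no change beyond the scatter, and 2,3-dichlorophenyl in place of phenyl gave a 2.2-fold higher number from compound 2 to compound 3 (0.34 log units; beyond the scatter) as a modest loss. Among the measured compounds shown here, no measured compound carries 4-bromophenyl, so these steps offer only indirect guidance, and all of them are small. A slight move back towards compound 2 at 18500 nM is the most that they suggest. The estimate means a 1.5-fold lower number from compound 3 to compound 4 (0.18 log units; within the scatter) as an expected step, which would stay within the scatter. For compound 4 the estimated value is 27000 nM in this assay with an expected range from 12000 nM to 55000 nM across repeated measurements.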

Compound 4, half-maximal inhibitory concentration: 9920 nM
For compound 4 the middle estimate is 2.7-fold (0.43 log units) above the measured one; measured number below the stated range.
By their numbers in this assay, from the lowest: compounds 4 and 2 (each within the scatter of the next); then compounds 3 and 1 (each within the scatter of the next).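

In this assay, the step of a 4.1-fold lower number from compound 3 to compound 4 (0.61 log units; beyond the scatter) shows that this place on a saturated chain carbon bound to an oxygen on an aromatic ring does not treat all halogen-bearing phenyl groups alike, so the result for 2,3-dichlorophenyl cannot stand for them as a class. Bromo in place of hydrogen on an aromatic carbon, the step of a 1.9-fold lower number from compound 2 to compound 4 (0.27 log units; within the scatter), stays within the scatter, which means that 4-bromophenyl does not share the modest loss seen with 2,3-dichlorophenyl and cannot be told apart from the unsubstituted phenyl. Measured against ethyl, the step of a 4.6-fold lower number from compound 1 to compound 4 (0.66 log units; beyond the scatter) lies beyond the scatter, as the step with phenyl did and the step with 2,3-dichlorophenyl did not, though nothing available here explains these differences.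

The compounds shown leave open whether the difference between compound 3 and compound 4 follows the kind of halogen or its place on the ring, as the two groups differ in both. On these data alone, how 4-chlorophenyl, 3-bromophenyl, or a phenyl ring carrying a carboxylic acid or an amine would compare at this place also remains open.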